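Ring substituent shift on the benzyl ether of the series

The compounds below may be only part of what the source reports. "The series", "measured", "known", "first", "only" and "open" are said of these compounds alone.

Measured so far:
- compound 1, `CCN(C(=O)c1ccccc1OCc1cccc(Cl)c1)C1CCCC(N)C1`, an assay on HEK293 cells for inhibition of transient receptor potential cation channel subfamily M member 8 (Homo sapiens), read by FLIPR and calcium flux; a lower number here means a stronger inhibitor, a higher number a weaker inhibitor: 96.9 nM
- compound 2, `CCN(C(=O)c1ccccc1OCc1ccccc1C#N)C1CCCC(N)C1`, this assay: 1850 nM

For the measured compounds named here, compound 2 holds the highest of the two numbers; the only neighbour is compound 1, and the step of a 19-fold higher number from compound 1 to compound 2 (1.28 log units; beyond the scatter) is large and beyond the scatter. Compound 3, `CCN(C(=O)c1ccccc1OCc1ccc(C#N)cc1)C1CCCC(N)C1`, is not yet measured. It differs from compound 2 by 4-cyanophenyl in place of 2-cyanophenyl on a saturated chain carbon bound to an oxygen on an aromatic ring. Going by the values given here, no measured step moves a nitrile from one ring position to another; the single step from compound 1 to compound 2 changes both the group and its position, so it shows only that this part of the molecule is sensitive, not which way a pure position shift goes. A modest change is therefore expected, with direction uncertain; the step is estimated as a 1.9-fold lower number from compound 2 to compound 3 (0.27 log units; within the scatter). For compound 3 the expected value in this assay is 1000 nM, within the range 200 nM to 5000 nM.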

Compound 3, half-maximal inhibitory concentration: 6780 nM
For compound 3 the middle estimate is 6.8-fold (0.83 log units) below the measured one; the measured number lies above the stated range.
By their numbers in this assay, from the lowest: compound 1; then compound 2; then compound 3.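

Moving the nitrile alone, with no change of group, is a real change in this assay: 4-cyanophenyl in place of 2-cyanophenyl gives (a 3.7-fold higher number from compound 2 to compound 3 (0.56 log units; beyond the scatter)), so position on this ring matters by itself, and of these two positions the 2-cyanophenyl gives the lower number. The 3-chlorophenyl of compound 1 stays well ahead of this nitrile as well (a 70-fold higher number from compound 1 to compound 3 (1.84 log units; beyond the scatter)), so neither nitrile position shown comes near it. Nothing at hand gives a reason for either step.

Still open, as far as these compounds go, is how 3-cyanophenyl would read, since it would separate the change of group from the change of position against compound 1. Also open, from the compounds shown here alone, is whether 2-chlorophenyl and 4-chlorophenyl would follow the same order as the two nitriles.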